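Replacing an Open Amine Chain with 4-Methylpiperazin-1-yl

The source may report more compounds than this note shows. Statements on the series, on what has been measured and on what is new or still open speak of the compounds shown alone.

In a functional assay on HCC827 cells (Homo sapiens) for antiproliferative activity, read by MTT assay, with a stated time of 72 h (on this read-out higher numbers stand for weaker inhibition and lower numbers for stronger inhibition), compound 1 (`CN1CCN(c2ccc(Nc3ncc4nc(SCc5ccccc5)n(C5CCOCC5)c4n3)cc2)CC1`) gives 107 nM and compound 2 (`CN1CCN(c2ccc(Nc3ncc4nc([S+]([O-])c5ccccc5)n([C@H]5CC[C@H](O)CC5)c4n3)cc2)CC1`) gives 268 nM. Compound 3 (`CN(C)CCN(C)c1ccc(Nc2ncc3nc([S+]([O-])c4ccccc4)n(C4CCOCC4)c3n2)cc1`) gives 1330 nM, the highest of the three numbers and beyond the scatter of both others, which makes it the weakest of this small set. Compound 4 (`CN1CCN(c2ccc(Nc3ncc4nc([S+]([O-])c5ccccc5)n(C5CCOCC5)c4n3)cc2)CC1`) departs from compound 3 in one place: 4-methylpiperazin-1-yl in place of (2-(dimethylamino)ethyl)(methyl)amino on an aromatic carbon. 4-Methylpiperazin-1-yl takes the place of (2-(dimethylamino)ethyl)(methyl)amino on an aromatic carbon, para to a large group. Within the data shown here, no measured pair shows this change alone, so the evidence is indirect. Compound 1 at 107 nM and compound 2 at 268 nM both carry 4-methylpiperazin-1-yl, though each also differs from compound 4 elsewhere. Both numbers lie well under that of compound 3. In this assay the expected step is a 6.7-fold lower number from compound 3 to compound 4 (0.82 log units; beyond the scatter), towards a lower number and beyond the scatter. For compound 4 the estimated value is 200 nM, with an expected range of 70 nM to 550 nM.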

Compound 4, half-maximal inhibitory concentration: 411 nM
Estimate against measurement, compound 4: 2.1-fold (0.31 log units) below; low and high end bracket the measured number.
By their numbers in this assay, from the lowest: compound 1; then compounds 2 and 4 (each within the scatter of the next); then compound 3.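

In this assay, 4-methylpiperazin-1-yl in place of the open (2-(dimethylamino)ethyl)(methyl)amino chain gives a 3.2-fold lower number from compound 3 to compound 4 (0.51 log units; beyond the scatter), so this position on the aromatic carbon, para to a large group, responds to the ring form of the amine on a direct comparison. With that ring held in place, oxan-4-yl in place of 4-hydroxycyclohexyl on the aromatic nitrogen gives a 1.5-fold higher number from compound 2 to compound 4 (0.19 log units; within the scatter), whereas the exchange of the sulfur-bearing group on an aromatic carbon gives a 3.8-fold higher number from compound 1 to compound 4 (0.58 log units; beyond the scatter), a change that matters here as much as the amine swap does. No available evidence accounts for any of these steps.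

From the compounds shown here alone, whether the step from the open chain to the ring would recur with 4-hydroxycyclohexyl on the aromatic nitrogen remains open. So does how a morpholin-4-yl or a piperidin-1-yl group would read at the same aromatic carbon.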